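The source may report more compounds than this note shows. Statements on the series, on what has been measured and on what is new or still open speak of the compounds shown alone.

Measured compounds:
- compound 1 `CCCC[N+](C)(C)CCCC(=O)[O-]`: > 1000000 nM
- compound 2 `C[N+](C)(CCCC(=O)[O-])CC1CCC1`: > 1000000 nM
- compound 3 `CC(C)[N+](C)(C)CCCC(=O)[O-]`: 5700 nM

Within the data shown here, in an assay for inhibition of gamma-butyrobetaine dioxygenase (Homo sapiens), read by HPLC, with stated times of 15 min and 30 min (on this read-out higher numbers stand for weaker inhibition and lower numbers for stronger inhibition), compound 3 gives the only real number among the three. The value of compound 1 in this assay is a limit of the assay, not a number. The value of compound 2 in this assay is likewise a limit. Compound 4 `C[N+](C)(CBr)CCCC(=O)[O-]` has not yet been measured. It differs from compound 3 in one place: bromomethyl in place of isopropyl on an amine nitrogen.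

Among the measured compounds shown here, only one measured step bears on changing the group on the amine nitrogen: an at least 170-fold lower number from compound 1 to compound 3 (2.24 log units; beyond the scatter), a large step in favour of the smaller group. The step that the two limits leave unreadable from compound 1 to compound 2 cannot be read because the limit of > 1000000 nM in this assay, at which 2 of the 3 values shown sit, is where both of its values sit. Bromomethyl is smaller again than isopropyl, so a further small gain in this assay is expected, though with only one readable step the uncertainty is wide. Compound 4 is expected to give about 3000 nM in this assay, within 500 nM to 30000 nM, which means an estimated step of a 1.9-fold lower number from compound 3 to compound 4 (0.28 log units; within the scatter).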

Compound 4, half-maximal inhibitory concentration: > 1000000 nM
Compound 4 gave a limit, no number; the forecaster's own chance of this, stated with the estimate: 15%; at least 330-fold (2.52 log units) between middle value and limit.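

In this assay compound 4 gives only a limit of the assay, not a number. Even so, this assay shows an at least 170-fold higher number from compound 3 to compound 4 (2.24 log units; beyond the scatter) on swapping isopropyl for bromomethyl, so a group with fewer heavy atoms on an amine nitrogen does not keep the gain seen in an at least 170-fold lower number from compound 1 to compound 3 (2.24 log units; beyond the scatter) for the change from butyl to isopropyl, which means the heavy-atom count of the group does not by itself set the result among these compounds. The steps from compound 1 and from compound 2 to compound 4 cannot be read because both ends of each are limits: the limit of > 1000000 nM in this assay, at which 3 of the 4 values shown sit.

From the compounds shown here alone, what remains open is whether the loss goes with the bromine or with the single carbon that carries it. An ethyl or a chloromethyl group on the same nitrogen would separate these two readings.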